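Fluorine for Chlorine on the Chalcone Aryl Ring

This account rests on a few compounds, and the source may have more. Where it says the series, first, only, none or still open, it means among the compounds named here.

Measured compounds:
compound 1 `COc1cc(-c2cc(/C=C/C(=O)c3ccc(Cl)c(Cl)c3)[nH]n2)cc(OC)c1OC` 31%
compound 2 `COc1ccc(-c2cc(/C=C/C(=O)c3cc(OC)c(OC)c(OC)c3)[nH]n2)cc1OC` -41%
compound 3 `COc1cc(C(=O)/C=C/c2cc(-c3cc(OC)c(OC)c(OC)c3)n[nH]2)cc(OC)c1OC` -51%

Of the compounds shown here, three share a core and have been read in a functional assay on NCI-H460 cells (Homo sapiens) for cytotoxicity, read by sulforhodamine B assay, with a stated time of 48 h, tested at 10 uM; on this read-out lower numbers stand for a stronger effect and higher numbers for a weaker effect at the one concentration tested. Compound 1 gives 31%, the highest of the three numbers and therefore the weakest effect among them. Compound 2 gives -41% and compound 3 gives -51%; both sit far below compound 1, beyond the scatter, while a number 10 percentage points lower from compound 2 to compound 3 (within the scatter) lies within it.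

Compound 4 `COc1cc(-c2cc(/C=C/C(=O)c3ccc(F)c(F)c3)[nH]n2)cc(OC)c1OC` is not yet measured. It differs from compound 1 in one place: 3,4-difluorophenyl in place of 3,4-dichlorophenyl on a carbonyl carbon.

Within the data shown here, no measured step touches this kind of change. Among the measured compounds shown here, the only step on record, from compound 2 to compound 3, concerns a methoxy group on a different ring and is within the scatter, so it says nothing about swapping one halogen pair for another. For the measured compounds named here, the two compounds with a trimethoxyphenyl ketone give strongly negative numbers, but that exchange is much larger than the one from compound 1 to compound 4 and cannot be carried over.

Going by the values given here, with no bearing step, compound 4 is expected to stay close to compound 1, and the estimated a number 4 percentage points higher from compound 1 to compound 4 (within the scatter) is not expected to exceed the scatter. Compound 4 is estimated at 35%, within the range 5% to 65%.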

Compound 4, a percentage reported as activity, at one concentration (the size of the read-out at that concentration, not a potency): -9%
For compound 4 the middle estimate is 44 percentage points above the measured one, outside the stated range (below it).
By their numbers in this assay, from the lowest: compounds 3 and 2 (each within the scatter of the next); then compound 4; then compound 1.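

In this assay, the group on the carbonyl carbon proves sensitive to the identity of its halogen pair: 3,4-difluorophenyl in place of 3,4-dichlorophenyl gives a number 40 percentage points lower from compound 1 to compound 4 (beyond the scatter). The earlier compounds shown here offered no step at this position, and this one shows a large shift from a change that leaves the heavy-atom count, the aromatic ring, the hydrogen-bond donor and acceptor counts and the net charge as they were, with compound 1 at 31% and compound 4 at -9%, on opposite sides of zero. Nothing available accounts for the size of this step, which stands here as an observation without an explanation.

The compounds shown leave open whether the read-out follows the kind of halogen or the presence of both halogens, which a phenyl group without substituents or one carrying a trifluoromethyl group on the same carbonyl carbon would help to separate. They also leave open whether the same exchange would give a step of similar size on the core of compound 2, where the other aryl group differs.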